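The source may hold more compounds than are shown below. What is called first, only, known or untested is meant among the compounds shown, and "the series" means these compounds.

In an ADME assay for permeability, using PAMPA, at pH 7.4 (a lower number here means that the compound crosses the layer more slowly, a higher number that the compound crosses the layer faster), three compounds have been measured: compound 1 `Cc1cc(NC(=O)Nc2ccccc2N)c2ccccc2n1` gives 300 10^-6 cm/s, compound 2 `Cc1cc(NC(=O)Nc2ccc(F)c(F)c2)c2ccccc2n1` gives 478 10^-6 cm/s, and compound 3 `Cc1cc(NC(=O)Nc2ccc(F)cc2)c2ccccc2n1` gives 801 10^-6 cm/s. Compound 2 stands within the scatter of both others. Compound 4 `COc1ccc(NC(=O)Nc2cc(C)nc3ccccc23)cc1F` departs from compound 2 by one exchange, (methoxy in place of fluoro on an aromatic carbon), that is, methoxy in place of fluoro on an aromatic carbon. Going by the values given here, no measured step makes this exchange. The closest parallel, a 1.7-fold higher number from compound 2 to compound 3 (0.22 log units; within the scatter), also replaces a fluoro, with hydrogen, and stays within the scatter. The other step, a 2.7-fold higher number from compound 1 to compound 3 (0.43 log units; beyond the scatter), changes a whole group on an amide-type nitrogen and is modest. No change beyond the scatter is therefore expected in this assay. The estimated step is a 1.1-fold lower number from compound 2 to compound 4 (0.06 log units; within the scatter). For compound 4 the estimated value is 420 10^-6 cm/s, with an expected range from 190 10^-6 cm/s to 850 10^-6 cm/s.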

Compound 4, apparent permeability: 50 10^-6 cm/s
Estimate against measurement, compound 4: 8.4-fold (0.92 log units) above; the whole stated range lies above it.
By their numbers in this assay, from the lowest: compound 4; then compounds 1, 2 and 3 (each within the scatter of the next, the first and the last beyond it).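

In this assay methoxy in place of fluoro on the aromatic carbon para to a large group gives a 9.6-fold lower number from compound 2 to compound 4 (0.98 log units; beyond the scatter) and so shows that this position is sensitive to the exchange. Compound 2 and compound 3 both carry fluoro on this carbon, so the earlier step from fluoro to hydrogen left it untouched. No measurement at hand explains the drop. The compounds shown leave open whether it follows the oxygen or the added heavy atom, which a methyl group or an ethoxy group on the same carbon could help separate.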